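Swapping methyl for bromo on compound 1

The source may hold more compounds than are shown below. What is called first, only, known or untested is meant among the compounds shown, and "the series" means these compounds.

Compound 1 `Cc1cccc(Oc2nn(C(C)(C)C)c3ncnc(N)c23)c1` gives 0.07 h
Compound 2 `CC(C)(C)n1nc(Sc2cccc(Cl)c2)c2c(N)ncnc21` gives 0.04 h
Compound 3 `Nc1ncnc2c1c(Oc1cccc(Cl)c1)nn2CC1CCOCC1` gives 0.233 h

For the measured compounds named here, these three values come from an ADME assay on microsomes from liver (Rattus norvegicus) for metabolic stability, read by LC-MS, tested at 1 uM (on this read-out higher numbers stand for a longer-lived compound and lower numbers for a shorter-lived compound), and no two of the compounds differ in one place only. Compound 1 at 0.07 h lies within the scatter of compound 2 at 0.04 h on this read-out. Compound 3 at 0.233 h stands higher than compound 1, beyond the scatter.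

Compound 4 `CC(C)(C)n1nc(Oc2cccc(Br)c2)c2c(N)ncnc21` has not yet been measured. It differs from compound 1 by a single change, (bromo in place of methyl on an aromatic carbon), which is bromo in place of methyl on an aromatic carbon, so that 3-methylphenyl becomes 3-bromophenyl.

Going by the values given here, no measured pair shows this change on its own, so the data give no direct size for it. The expectation therefore stays at the level of compound 1, which has a half-life of 0.07 h in this assay. No step beyond the scatter is expected, and the estimated change is a 1.1-fold higher number from compound 1 to compound 4 (0.06 log units; within the scatter) on this read-out. For compound 4 the expected half-life is 0.08 h, with a range of 0.04 h to 0.17 h around that estimate.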

Compound 4, half-life: 0.103 h
The estimate for compound 4 lay 1.3-fold (0.11 log units) below the measured number, within the range that was stated.
By their numbers in this assay, from the lowest: compounds 2, 1 and 4 (each within the scatter of the next, the first and the last beyond it); then compound 3.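

For the compounds shown here, for the first time, a pair that differs in one place gives a direct size for a change: in this assay, bromo in place of methyl on an aromatic carbon gives a 1.5-fold higher number from compound 1 to compound 4 (0.17 log units; within the scatter). On this read-out, then, the 3-methylphenyl and 3-bromophenyl compounds cannot be told apart, so this one position, meta to a large group on the six-membered aromatic ring, accepts either group without a step beyond the usual scatter. Nothing available explains why the two groups read alike, and no outside information bears on this result.

As far as these compounds go, whether a group of another kind at this position, such as an amine, a carboxylic acid or a methoxy group, would give a step beyond the scatter remains open. One pair also leaves open whether bromo in place of methyl would read the same way with the sulfur link of compound 2 or with the side chain of compound 3, since each of those compounds differs from compound 1 in more than the aryl group.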